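Removing halogens from the anilide ring of compound 3

The compounds below may be only part of what the source reports. "The series", "measured", "known", "first", "only" and "open" are said of these compounds alone.

Measured compounds:
- compound 1, `CN(C)C(=O)c1cc2cnc(Nc3ccc(NC(=O)C4(C(=O)Nc5ccccc5)CC4)cc3)nc2n1C1CCCC1`: 52.8%
- compound 2, `CN(C)C(=O)c1cc2cnc(Nc3ccc(NC(=O)C4(C(=O)Nc5ccc(Br)cc5)CC4)cc3)nc2n1C1CCCC1`: 21.1%
- compound 3, `CN(C)C(=O)c1cc2cnc(Nc3ccc(NC(=O)C4(C(=O)Nc5ccc(Cl)c(C(F)(F)F)c5)CC4)cc3)nc2n1C1CCCC1`: 6.9%

These three compounds share one core and differ only in the aryl group on the amide-type nitrogen. In a functional assay on T47D cells (Homo sapiens) for inhibition, read by CCK-8 assay, with a stated time of 72 h, tested at 1 uM (on this read-out lower numbers stand for less inhibition of growth and higher numbers for more inhibition of growth at the one concentration tested), compound 3 stands lowest of the three numbers; its nearest neighbour is compound 2 and its furthest is compound 1, both steps beyond the scatter.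

Compound 4, `Cc1ccc(NC(=O)C2(C(=O)Nc3ccc(Nc4ncc5cc(C(=O)N(C)C)n(C6CCCC6)c5n4)cc3)CC2)cc1`, has not yet been measured. It differs from compound 3 in one place: 4-methylphenyl in place of 4-chloro-3-(trifluoromethyl)phenyl on an amide-type nitrogen.

Among the measured compounds shown here, three measured steps bear on this change. The step of a number 45.9 percentage points lower from compound 1 to compound 3 (beyond the scatter) shows that moving from plain phenyl to 4-chloro-3-(trifluoromethyl)phenyl removed most of the growth inhibition; the step of a number 31.7 percentage points lower from compound 1 to compound 2 (beyond the scatter) shows that bromo in place of hydrogen alone did much of that; and the step of a number 14.2 percentage points lower from compound 2 to compound 3 (beyond the scatter) was smaller. Compound 4 carries a methyl where compound 2 carries bromo and compound 1 carries hydrogen, so an upward step is expected in this assay, probably landing between the values of compound 1 and compound 2.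

The step is estimated as a number 28.1 percentage points higher from compound 3 to compound 4 (beyond the scatter). Compound 4 is therefore expected to give about 35%, with a range from 15% to 55%.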

Compound 4, percent growth inhibition at one concentration: 47.9%
Estimate against measurement, compound 4: 12.9 percentage points below, within the range that was stated.
By their numbers in this assay, from the lowest: compound 3; then compound 2; then compounds 4 and 1 (each within the scatter of the next).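

In this assay, the step of a number 41 percentage points higher from compound 3 to compound 4 (beyond the scatter) shows that this position on the amide-type nitrogen can lose its halogens and trifluoromethyl and return to the level of the unsubstituted anilide, with 4-methylphenyl in place of 4-chloro-3-(trifluoromethyl)phenyl. A substituent on that aromatic carbon is therefore not in itself a penalty: methyl in place of hydrogen gives a number 4.9 percentage points lower from compound 1 to compound 4 (within the scatter), while methyl in place of bromo gives a number 26.8 percentage points higher from compound 2 to compound 4 (beyond the scatter), so among these four compounds the low numbers belong to the two that carry halogen, and the methyl compound stays with the plain phenyl. Nothing measured here explains why methyl and bromo part so far on this read-out.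

Compound 3 carries chloro and trifluoromethyl together, so the compounds shown leave open what either group would do alone on the phenyl ring. Also open, going by these compounds, is how a methoxy group, an amine or a carboxylic acid in place of the methyl would read, and whether a longer alkyl chain there would keep the level of compound 4.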